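The source may hold more compounds than are shown below. What is called first, only, known or untested is meant among the compounds shown, and "the series" means these compounds.

Measured: compound 1 `OC[C@@H](O[C@H]1CCCN(Cc2ncc[nH]2)[C@H]1c1ccccc1)c1cc(Cl)cc(Cl)c1` gives 47000 nM in an assay on isolated protein for activation of cGMP-dependent protein kinase 1 (Homo sapiens), read by ADP-Glo, with stated times of 30 min and 2 h, in the presence of a further agent that is not named here; a higher number here means that more compound is needed for the effect, a lower number that less compound is needed; compound 2 `Cc1cc(C(=O)O)ccc1C(C)N1CCC[C@H](O[C@H](CO)c2cc(Cl)cc(Cl)c2)[C@@H]1c1ccccc1` gives 18000 nM in this assay.

Compound 2 stands at the lower of the two numbers, compound 1 at the higher, the gap being a 2.6-fold lower number from compound 1 to compound 2 (0.42 log units; beyond the scatter). Compound 3 `OC[C@@H](O[C@H]1CCCN(Cc2nc3ccccc3[nH]2)[C@H]1c1ccccc1)c1cc(Cl)cc(Cl)c1` carries a group of 10 heavy atoms (8 carbon, 2 nitrogen; one five-membered aromatic ring with 2 hetero atoms, one six-membered aromatic ring of carbon only) in place of a group of 12 heavy atoms (10 carbon, 2 oxygen; one six-membered aromatic ring of carbon only), on an amine nitrogen in a ring. For the measured compounds named here, the one measured step at this ring nitrogen exchanged a five-membered aromatic ring with 2 hetero atoms for the group of 12 heavy atoms and lowered the number; compound 3 reverses most of that exchange, bringing back such a ring fused to a six-membered aromatic ring of carbon only, so a modest rise is expected, a 1.9-fold higher number from compound 2 to compound 3 (0.29 log units; within the scatter). Compound 3 is estimated at 35000 nM, range 12000 nM to 110000 nM.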

Compound 3, half-maximal effective concentration: 4700 nM
Compound 3: middle estimate off by 7.4-fold (0.87 log units), on the high side; measured number below the stated range.
By their numbers in this assay, from the lowest: compound 3; then compound 2; then compound 1.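

At the amine nitrogen in the ring, (1H-benzimidazol-2-yl)methyl gives the lowest number of the three groups in this assay, with a 3.8-fold lower number from compound 2 to compound 3 (0.58 log units; beyond the scatter) and a 10-fold lower number from compound 1 to compound 3 (1.00 log units; beyond the scatter). The second step adds only the fused six-membered aromatic ring of carbon only, and the first shows that the lowest number here does not require the carboxylic acid of compound 2. No evidence on hand accounts for these gains.

Still open, going by these compounds, is whether substituents on that fused ring, such as a methoxy group or an amine, lower the number further.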